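Moving from compound 2 to compound 4 in a cellular assay

The compounds below may be only part of what the source reports. "The series", "measured", "known", "first", "only" and "open" are said of these compounds alone.

Compound 1 `COc1cc(/C=C/C(=O)Nc2cc3c(Nc4ccc(F)c(Cl)c4)ncnc3cc2OC)cc(OC)c1` — "not determined" (no result reported).
Compound 2 `COc1cc(/C=C/C(=O)Nc2cc3c(Nc4ccc(F)c(Cl)c4)ncnc3cc2O[C@H]2CCOC2)cc(OC)c1` — 34300 nM.
Compound 3 `COc1cc2ncnc(Nc3ccc(F)c(Cl)c3)c2cc1NC(=O)/C=C/c1ccc(C#N)cc1` — "not determined" (no result reported).

Going by the values given here, in a functional assay on HeLa cells (Homo sapiens) for cytotoxicity, read by MTT assay, with a stated time of 72 h (a lower number here means a stronger inhibitor, a higher number a weaker inhibitor), compound 2 gives 34300 nM, the only number among the three measured compounds, since compound 1 and compound 3 carry no result in this assay. Compound 2 therefore stands alone, and it stands as a weak inhibitor. Compound 4 `O=C(/C=C/c1ccccc1[N+](=O)[O-])Nc1cc2c(Nc3ccc(F)c(Cl)c3)ncnc2cc1O[C@H]1CCOC1` differs from compound 2 in one place: 2-nitrophenyl in place of 3,5-dimethoxyphenyl on a double-bonded chain carbon bound to a double-bonded chain carbon. Among the compounds with values here, no step between two measured compounds is available to size this change, so the expected step from compound 2 to compound 4 is judged to be a 1.1-fold lower number from compound 2 to compound 4 (0.06 log units; within the scatter), a step not clearly beyond the scatter in either direction. Compound 4 is accordingly expected to give about 30000 nM, within a range from 10000 nM to 90000 nM.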

Compound 4, half-maximal inhibitory concentration: 29600 nM
Estimate against measurement, compound 4: 1.0-fold (0.01 log units) above; the range from low to high includes it.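

In this assay, putting 2-nitrophenyl in place of 3,5-dimethoxyphenyl on a double-bonded chain carbon bound to a double-bonded chain carbon gives a 1.2-fold lower number from compound 2 to compound 4 (0.06 log units; within the scatter), the first step readable at this position. This assay therefore does not separate the two substituted phenyl groups, despite their different substituents. No evidence at hand bears on the reason for this. On these data alone, it remains open whether a phenyl ring carrying an amine or a carboxylic acid, or a longer chain in this place, would give a step beyond the scatter.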